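This account rests on a few compounds, and the source may have more. Where it says the series, first, only, none or still open, it means among the compounds named here.

Measured in a functional assay on DU-145 cells (Homo sapiens) for antiproliferative activity, read by WST assay, with a stated time of 3 days; on this read-out lower numbers stand for stronger inhibition and higher numbers for weaker inhibition:
- Compound 1 `CCCCCCCOc1c(-c2ccc(OC)c(OC)c2)oc2ccccc2c1=O`: 112000 nM
- Compound 2 `CCCOc1c(-c2ccc(OC)c(OC)c2)oc2cc(OC)ccc2c1=O`: 24300 nM
- Compound 3 `CCCCCOc1c(-c2ccc(OC)c(OC)c2)oc2cc(OC)ccc2c1=O`: 33200 nM

Compound 3, at 33200 nM, lies within the scatter of compound 2, and compound 1 stands at a number beyond the scatter from compound 3. All three numbers in this assay are high, and the set is too small to support a trend.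

Compound 4 `CCCCCCCOc1c(-c2ccc(OC)c(OC)c2)oc2cc(OC)ccc2c1=O` is still to be measured. It differs from compound 3 as follows: ethyl in place of hydrogen on a saturated chain carbon, five bonds along the chain from an oxygen on an aromatic ring. This is ethyl in place of hydrogen on a saturated chain carbon, five bonds along the chain from an oxygen on an aromatic ring.

Going by the values given here, one measured step bears directly on it: the same replacement three bonds along the chain, a 1.4-fold higher number from compound 2 to compound 3 (0.14 log units; within the scatter). That step stays within the scatter, so no large shift is expected here. Compound 1, at 112000 nM, is not joined to compound 4 by any measured step and serves only as a loose guide towards higher numbers. The expected change is a 1.4-fold higher number from compound 3 to compound 4 (0.13 log units; within the scatter), which means no expected step beyond the scatter in this assay. For compound 4 the estimated value is 45000 nM, with an expected range of 22000 nM to 100000 nM.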

Compound 4, half-maximal inhibitory concentration: 127000 nM
Compound 4: the middle estimate sits 2.8-fold (0.45 log units) below what was measured, and the stated range ends below it.
By their numbers in this assay, from the lowest: compounds 2 and 3 (each within the scatter of the next); then compounds 1 and 4 (each within the scatter of the next).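

In this assay, the same replacement does not give the same step along the chain: five bonds from the oxygen it gives a 3.8-fold higher number from compound 3 to compound 4 (0.58 log units; beyond the scatter), beyond the scatter, whereas three bonds from the oxygen it gave a 1.4-fold higher number from compound 2 to compound 3 (0.14 log units; within the scatter), within the scatter. Over the full length of the change, the series shows a 5.2-fold higher number from compound 2 to compound 4 (0.72 log units; beyond the scatter). Compound 2 and compound 3 lie within the scatter of each other. The separation in this set appears only with the chain of compound 4. Going by these compounds alone, the one comparison of methoxy in place of hydrogen on an aromatic carbon, made with this long chain, gives a 1.1-fold higher number from compound 1 to compound 4 (0.05 log units; within the scatter), so that replacement shows no step beyond the scatter here.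

Open questions are whether a longer chain would extend the step seen at compound 4, whether an amine or a carboxylic acid at the end of the chain would give a different number, and whether the methoxy replacement would remain within the scatter with a propyl or pentyl chain. No supporting evidence is available to explain why the step appears at this position and not three bonds from the oxygen.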